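The source may hold more compounds than are shown below. What is called first, only, known or untested is meant among the compounds shown, and "the series" means these compounds.

Three compounds that act on an assay on forebrain for inhibition of Monoamine oxidase (Mus musculus) (on this read-out lower numbers stand for an effect already at smaller amounts and higher numbers for an effect only at larger amounts of compound), have been measured. Compound 1 `C=C=CCN(C)Cc1ccccc1` gives 17 umol/kg in this assay. Compound 2 `C=C=C(CN)Cc1ccccc1` gives 12 umol/kg, and compound 3 `C=C=C(CNC)Cc1ccccc1` gives 11 umol/kg. Compound 1 and compound 3 are made of the same atoms joined differently; the difference between the two cores is not broken down here. Compound 3 and compound 2 differ in one place, (hydrogen in place of methyl on an amine nitrogen), and that change brought a 1.1-fold higher number from compound 3 to compound 2 (0.04 log units; within the scatter).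

Compound 4 `C=C=CCNCc1ccccc1` has not yet been measured. It arises from compound 1 by the same kind of change, (hydrogen in place of methyl on an amine nitrogen), although the surroundings are not identical: in compound 1 the amine nitrogen has two saturated chain carbons as its other neighbours, whereas in compound 3 it has one saturated chain carbon. Because the matching step gave a 1.1-fold higher number from compound 3 to compound 2 (0.04 log units; within the scatter), a change of similar size is expected here, namely a 1.1-fold higher number from compound 1 to compound 4 (0.02 log units; within the scatter). Compound 4 is therefore estimated to give 18 umol/kg in this assay, with a range from 9 umol/kg to 36 umol/kg considered plausible.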

Compound 4, dose for half-maximal effect: 6 umol/kg
For compound 4 the middle estimate is 3.0-fold (0.48 log units) above the measured one; measured number below the stated range.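

In this assay, hydrogen in place of methyl on an amine nitrogen gave a 2.8-fold lower number from compound 1 to compound 4 (0.45 log units; beyond the scatter) on the core of compound 1, and this does not match what the same change did on the other core: the same change on two cores in this assay, a 1.1-fold higher number (0.04 log units; within the scatter) from compound 3 to compound 2 and a 2.8-fold lower number (0.45 log units; beyond the scatter) from compound 1 to compound 4, 3.1-fold (0.49 log units) apart, beyond the scatter of two such steps. The size of this step therefore did not carry from one core to the other in this series, so a step read on one of these cores is a poor guide to the same step on the other. For the compounds shown here, this rests on only two pairs, however; it shows that the two steps differ, but not which feature of the two cores sets them apart, nor how the change would behave on any further core.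

The compounds shown leave open what happens when the amine nitrogen carries an ethyl group or a longer chain instead of hydrogen or methyl, on either core. They also leave open whether such a group would keep the two cores apart in the same way.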